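Lengthening the Amide Methyl in a Weak Series

A few compounds are considered here, and "the series" means these few. Any claim that something is new, unique, unknown or untested is made for them only; others in the source may bear on it.

Of the compounds shown here, three with a shared core have been tested in a functional assay on HT-29 cells (Homo sapiens) for inhibition, read by MTT assay, with a stated time of 48 h; on this read-out higher numbers stand for weaker inhibition and lower numbers for stronger inhibition. Compound 1 `O=C1CN(C2CCCC2)c2nc(Nc3ccc(N4CCCCC4)cn3)ncc2N1` gives 21100 nM in this assay. Compound 2 `CN1C(=O)CN(C2CCCC2)c2nc(Nc3ccc(N4CCCCC4)cc3)ncc21` gives 9860 nM in this assay. Compound 3 `CC1CCN(c2ccc(Nc3ncc4c(n3)N(C3CCCC3)CC(=O)N4C)cc2)CC1` reaches only > 30000 nM in this assay, which is a limit of the assay and not a number. Within the measured set there is an at least 3.0-fold higher number from compound 2 to compound 3 (0.48 log units; beyond the scatter), so compound 3 stands at the limit of > 30000 nM in this assay, at which 1 of the 3 values shown sits, weaker than compound 2 by an amount that is only bounded from below.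

Compound 4 `CCN1C(=O)CN(C2CCCC2)c2nc(Nc3ccc(N4CCC(C)CC4)cc3)ncc21` differs from compound 3 by methyl in place of hydrogen on a saturated chain carbon bound to an amide-type nitrogen in a ring. Going by the values given here, no measured pair shows this kind of change; the only step available, an at least 3.0-fold higher number from compound 2 to compound 3 (0.48 log units; beyond the scatter), concerns a methyl on a saturated ring carbon and does not bear on the amide-bound carbon. Since compound 3 already sits at the limit, the change is expected to leave the number at or beyond that limit, with a step that the limit leaves unreadable from compound 3 to compound 4. Compound 4 is therefore estimated at 35000 nM in this assay, within a range from 15000 nM to 90000 nM, and most likely to be reported again as a limit rather than a number.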

Compound 4, half-maximal inhibitory concentration: 24400 nM
Compound 4: the middle estimate sits 1.4-fold (0.16 log units) above what was measured; the measured number falls inside the stated range.
By their numbers in this assay, from the lowest: compound 2; then compounds 1 and 4 (each within the scatter of the next). At a limit, above all of these: compound 3.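

Going by these compounds alone, the methyl to ethyl change, on a saturated chain carbon bound to an amide-type nitrogen in a ring, is the first change at this place that can be read, and it leaves compound 4 with a number rather than a limit. In this assay, compound 3 gives > 30000 nM, which is a limit of the assay and not a number. The step can be read only as an at least 1.2-fold lower number from compound 3 to compound 4 (0.08 log units; that floor lies within the scatter), so the added methyl brings no visible loss at this place, but the true size of the step stays unknown because one end of it is a limit: the limit of > 30000 nM in this assay, at which 1 of the 4 values shown sits.

The compounds shown leave open whether this place would also accept a longer chain such as propyl, or a chain ending in an amine or a carboxylic acid. They also leave open what the same methyl to ethyl change would do in compound 2, which gives 9860 nM, a number and not a limit, so that a step from it could be read in full.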